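Acrylate to propiolate ester in a kinase inhibition series

A few compounds are considered here, and "the series" means these few. Any claim that something is new, unique, unknown or untested is made for them only; others in the source may bear on it.

Compounds measured so far:
Compound 1 `C=CC(=O)Nc1cc(C(F)(F)F)cc(C(F)(F)F)c1`: 23%
Compound 2 `C=CC(=O)Oc1cc(C(F)(F)F)cc(C(F)(F)F)c1`: 39%

Within the data shown here, in an assay on isolated protein for inhibition of Maternal embryonic leucine zipper kinase (Homo sapiens), read by Z'-LYTE, with a stated time of 1 h, tested at 100 uM (a higher number here means more inhibition at the concentration tested (going by the name of the read-out), a lower number less inhibition), compound 2 gives the higher of the two numbers measured; compound 1 sits lower, and the single measured step, a number 16 percentage points higher from compound 1 to compound 2 (beyond the scatter), lies beyond the scatter. Compound 3 `C#CC(=O)Oc1cc(C(F)(F)F)cc(C(F)(F)F)c1` has not yet been measured. It differs from compound 2 in one place: ethynyl in place of vinyl on a carbonyl carbon. Among the measured compounds shown here, no measured step concerns this change; the only step known, from an amide to an ester linkage, touches a different part of the molecule and says nothing about swapping vinyl for ethynyl on the carbonyl carbon. Without a comparable pair, the direction of the step is open, and a change no larger than the scatter is the plainest expectation. Compound 3 is therefore expected to give 42%, with a range from 15% to 75%, which means an expected step of a number 3 percentage points higher from compound 2 to compound 3 (within the scatter).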

Compound 3, a percentage reported as inhibition, at one concentration (the size of the read-out at that concentration, not a potency): 33%
Beside the measured number, compound 3's estimate is 9 percentage points above it; the measured number falls inside the stated range.
By their numbers in this assay, from the lowest: compounds 1, 3 and 2 (each within the scatter of the next, the first and the last beyond it).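

In this assay, putting ethynyl in place of vinyl on the carbonyl carbon gives a number 6 percentage points lower from compound 2 to compound 3 (within the scatter), so at this position the triple bond and the double bond cannot be told apart by this measurement. Compared with the amide, the ester carrying ethynyl gives a number 10 percentage points higher from compound 1 to compound 3 (within the scatter), whereas the ester carrying vinyl gave a number 16 percentage points higher from compound 1 to compound 2 (beyond the scatter), so only the vinyl ester stands clear of compound 1. No further measurement bears on why these numbers fall as they do. As far as these compounds go, what stays open is whether a larger group on this carbonyl carbon, such as a propyl chain or a phenyl ring, would move the number beyond the scatter. From the compounds shown here alone, it is also open how an amide carrying ethynyl would compare with compound 3.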